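A few compounds are considered here, and "the series" means these few. Any claim that something is new, unique, unknown or untested is made for them only; others in the source may bear on it.

Working notes on the series in a functional assay on A549 cells (Homo sapiens) for cytotoxicity, read by MTT assay, with a stated time of 48 h; on this read-out higher numbers stand for weaker inhibition and lower numbers for stronger inhibition.

Of the compounds shown here, three have numbers so far. Compound 1 `CCOC(=O)c1c(-c2c(Cl)c3ccccc3oc2=O)nn(-c2cccc(C)c2)c1C(=O)OCC` gives 36000 nM in this assay. Compound 2 `CCOC(=O)c1c(-c2cc3ccccc3oc2=O)nn(-c2cccc(C)c2)c1C(=O)OCC` gives 52000 nM. Compound 3 `CCOC(=O)c1c(-c2cc3ccccc3oc2=O)nn(-c2ccc(OC)cc2)c1C(=O)OCC` gives 86000 nM. Compound 2 sits within the scatter of both neighbours: a 1.4-fold higher number from compound 1 to compound 2 (0.16 log units; within the scatter), and a 1.7-fold higher number from compound 2 to compound 3 (0.22 log units; within the scatter). Nothing among the three numbers separates one compound from another beyond the scatter.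

Compound 4 `CCOC(=O)c1c(-c2cc3cc(OC)ccc3oc2=O)nn(-c2cccc(C)c2)c1C(=O)OCC` is the next member and has no number yet. Against compound 2 the change is methoxy in place of hydrogen on an aromatic carbon, so the shared core is kept and only the fused two-ring part of the substituent gains a methoxy.

Going by the values given here, two measured steps bear on it, neither closely. The step from compound 1 to compound 2 alters a substituent on the same fused two-ring part, removing a chloro, and stays within the scatter: a 1.4-fold higher number from compound 1 to compound 2 (0.16 log units; within the scatter). The step from compound 2 to compound 3 brings in a methoxy, but on the aryl group at the nitrogen, and also stays within the scatter: a 1.7-fold higher number from compound 2 to compound 3 (0.22 log units; within the scatter). Among the compounds with values here, no measured step places a methoxy where compound 4 carries it. On this evidence no step beyond the scatter is expected for compound 4 in this assay, in either direction: a 1.0-fold lower number from compound 2 to compound 4 (0.02 log units; within the scatter). Compound 4 is therefore estimated at 50000 nM, with a range from 25000 nM to 100000 nM.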

Compound 4, half-maximal inhibitory concentration: 102000 nM
Estimate against measurement, compound 4: 2.0-fold (0.31 log units) below; measured number outside the range, above it.
By their numbers in this assay, from the lowest: compounds 1, 2, 3 and 4 (each within the scatter of the next, the first and the last beyond it).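

With this compound, a methoxy on an aromatic carbon of the fused two-ring part, meta to a fused ring and para to a fused ring, has its first measured step in this assay: a 2.0-fold higher number from compound 2 to compound 4 (0.29 log units; within the scatter). Even this change, the largest single step in the series so far, stays within the scatter, so the position accepts a methoxy in place of hydrogen with no step that can be told from repeat variation, as was already the case for the chloro step and the methoxy step on the aryl group at the nitrogen. Nothing measured alongside these numbers offers an explanation for this result.

Still open is whether any other group at this position, such as a hydroxy, an amine, a carboxylic acid or a longer chain, would give a step beyond the scatter, since only hydrogen and methoxy are shown here. Also open, on these data alone, is whether the same methoxy gives a comparable step when the 4-methoxyphenyl group sits on the aromatic nitrogen in place of 3-methylphenyl.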